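Swapping dimethylamino for ethyl at the solubility limit

The source may report more compounds than this note shows. Statements on the series, on what has been measured and on what is new or still open speak of the compounds shown alone.

Measured in a physicochemical assay for solubility, read by nephelometry; a higher number here means a more soluble compound, a lower number a less soluble compound:
- Compound 1 `CC1(C)C(=O)N(c2ccc(SC(F)(F)F)cc2)C(=O)N1Cc1ccnc(N2CCNCC2)c1`: < 0.024 ug/mL, a limit
- Compound 2 `CN(C)c1cc(CN2C(=O)N(c3ccc(SC(F)(F)F)cc3)C(=O)C2(C)C)ccn1`: < 0.022 ug/mL, a limit
- Compound 3 `CC1(C)C(=O)N(c2ccc(SC(F)(F)F)cc2)C(=O)N1Cc1ccnc(NC2CCCCC2)c1`: < 0.025 ug/mL, a limit

None of these three compounds has an exact reading. Compound 2 stands only at its limit of < 0.022 ug/mL.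

The next compound is compound 4 `CCc1cc(CN2C(=O)N(c3ccc(SC(F)(F)F)cc3)C(=O)C2(C)C)ccn1`, and the change is ethyl in place of dimethylamino on an aromatic carbon, next to the ring nitrogen.

Within the data shown here, three measured steps bear on this change, as each also swaps one group for another on an aromatic carbon: a step that the two limits leave unreadable from compound 1 to compound 2, a step that the two limits leave unreadable from compound 1 to compound 3 and a step that the two limits leave unreadable from compound 2 to compound 3. None of them has a readable size, so they give no direction to follow.

The expected move, a step that the limit leaves unreadable from compound 2 to compound 4, is therefore none beyond the scatter in this assay, and another limit is the likeliest report. For compound 4 the estimated solubility is 0.02 ug/mL, with an expected range of 0.006 ug/mL to 0.08 ug/mL.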

Compound 4, solubility: < 0.022 ug/mL
Compound 4: a limit, no number (the forecaster's own chance of this, stated with the estimate: 85%); the middle value lies beyond the limit too.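

Compound 4 gives < 0.022 ug/mL, a limit and not a number. Its steps to compound 1, compound 2 and compound 3 cannot be read. Whether ethyl, dimethylamino, cyclohexylamino and piperazin-1-yl differ at all in solubility stays open, with no exact reading among these four compounds.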